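From 4-chlorophenyl to 2,5-dihydroxyphenyl on a shared core

A few compounds are considered here, and "the series" means these few. Any claim that something is new, unique, unknown or untested is made for them only; others in the source may bear on it.

Of the compounds shown here, three have so far been measured in a functional assay, read by Griess assay, with a stated time of 2.5 h; on this read-out lower numbers stand for stronger inhibition and higher numbers for weaker inhibition. Compound 1 `COc1cc(OC)c(OC)cc1/C=C/C(=O)c1ccc(Cl)cc1` gives 2.01 ug/mL as its half-maximal value, compound 2 `COc1cc(OC)c(OC)cc1/C=C/C(=O)c1ccc(Cl)c([N+](=O)[O-])c1` gives 1.99 ug/mL and compound 3 `COc1cc(C(=O)/C=C/c2cc(OC)c(OC)cc2OC)ccc1O` gives 2.46 ug/mL in the same read-out. Compound 1 therefore stands among the other two, separated from neither by more than the scatter.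

Compound 4 `COc1cc(OC)c(OC)cc1/C=C/C(=O)c1cc(O)ccc1O` has no number yet. It carries 2,5-dihydroxyphenyl in place of 4-chlorophenyl on a carbonyl carbon and keeps the rest of compound 1 unchanged. Among the compounds with values here, only one measured step touches the 4-chlorophenyl group, namely nitro in place of hydrogen on an aromatic carbon. That step was small (a 1.0-fold lower number from compound 1 to compound 2 (0.00 log units; within the scatter)). Within the data shown here, no measured step isolates a hydroxy group, though compound 3, which bears one, stays close (2.46 ug/mL). No step beyond the scatter is therefore expected, and the estimated change is small (a 1.1-fold lower number from compound 1 to compound 4 (0.05 log units; within the scatter)). Compound 4 is estimated at 1.8 ug/mL (expected range 0.7 ug/mL to 4.5 ug/mL).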

Compound 4, half-maximal inhibitory concentration: 2.44 ug/mL
Compound 4: the middle estimate sits 1.4-fold (0.13 log units) below what was measured; the measured number falls inside the stated range.
By their numbers in this assay, from the lowest: compounds 2, 1, 4 and 3 (each within the scatter of the next).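

In this assay, the exchange of 4-chlorophenyl for 2,5-dihydroxyphenyl on a carbonyl carbon gives a 1.2-fold higher number from compound 1 to compound 4 (0.08 log units; within the scatter). The earlier step only added nitro to the 4-chlorophenyl group, whereas this one replaces the entire group, removing the chlorine and bringing in hydrogen-bond donors, and it still stays within the scatter, so the read-out at this position does not depend on keeping 4-chlorophenyl. No evidence is available that bears on the cause of this result.

The step does not separate the loss of the chlorine from the gain of either hydroxy group, and no compound shown moves the number beyond the scatter. On these data alone, it remains open whether an amine, a carboxylic acid or a longer chain on the carbonyl carbon of the shared core would do so.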